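Dropping the bromo of compound 2: cytotoxicity expectation

The compounds below may be only part of what the source reports. "The series", "measured", "known", "first", "only" and "open" are said of these compounds alone.

For the measured compounds named here, compound 2 `CCC1(Cc2ccccc2)OS(=O)(=O)C=C1OCc1ccc(Br)cc1` holds the only plain number in an ADME assay on HEL cells (Homo sapiens) for cytotoxicity, with a stated time of 3 days (a higher number here means that more compound is tolerated, a lower number that less compound is tolerated), where compound 2 gives 80000 nM. Compound 1 `CCC1(Cc2ccccc2)OS(=O)(=O)C=C1OCc1ccc(OC)cc1` returns only a limit in this assay, namely >= 200000 nM (the limit of >= 200000 nM in this assay, at which 1 of the 2 values shown sits). Going by the values given here, the single measured step, an at least 2.5-fold lower number from compound 1 to compound 2 (0.39 log units; beyond the scatter), is the sole guide. Compound 3 `CCC1(Cc2ccccc2)OS(=O)(=O)C=C1OCc1ccccc1` differs from compound 2 by hydrogen in place of bromo on an aromatic carbon; this is not the same exchange as in the measured step, so it serves only loosely. A modest move back toward higher tolerated concentration is expected, a 1.9-fold higher number from compound 2 to compound 3 (0.27 log units; within the scatter). For compound 3 the estimate in this assay is 150000 nM, with a range of 60000 nM to 300000 nM.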

Compound 3, minimum cytotoxic concentration: >= 50000 nM
Compound 3 gave a limit, no number; the forecaster's own chance of this, stated with the estimate: 40%; the middle value does not contradict the limit.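

Compound 3 returns only the limit >= 50000 nM in this assay and the steps to it from compound 1 and compound 2 cannot be read. Left open is whether hydrogen in place of bromo changes the tolerated concentration at all.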